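Removing the phenol hydroxy from a cytotoxicity-tested aryl scaffold

A few compounds are considered here, and "the series" means these few. Any claim that something is new, unique, unknown or untested is made for them only; others in the source may bear on it.

Measured compounds:
- compound 1 `Cc1cc(-c2ccc(O)cc2)c2ncc(CSCCc3ccccc3)n2c1` — 20 ug/mL in an ADME assay on HEL cells (Homo sapiens) for cytotoxicity, with a stated time of 3 days; a higher number here means that more compound is tolerated, a lower number that less compound is tolerated
- compound 2 `Cc1cc(-c2cccc(C#N)c2)cn2c(CSCCc3ccccc3)cnc12` — compound 2 sits at the limit > 100 ug/mL
- compound 3 `Cc1cc(-c2ccc(O)cc2)cn2c(CSCCc3ccccc3)cnc12` — compound 3 sits at the limit >= 100 ug/mL

Among the compounds with values here, compound 1 is the only compound of the three with a value reported as a number in this assay; the other two are limits. Within the data shown here, the one comparison available among the measured compounds, a step that the two limits leave unreadable from compound 2 to compound 3, cannot be read, since both ends are limits (the limit of > 100 ug/mL in this assay, at which 1 of the 3 values shown sits, and (the limit of >= 100 ug/mL in this assay, at which 1 of the 3 values shown sits)).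

Compound 4 `Cc1cc(-c2ccccc2)c2ncc(CSCCc3ccccc3)n2c1` differs from compound 1 in one place: hydrogen in place of hydroxy on an aromatic carbon. Among the measured compounds shown here, no measured pair isolates this change, so no step size can be taken from the data. For the measured compounds named here, compound 3 carries the same 4-hydroxyphenyl group as compound 1 on a differently arranged core and sits at a limit, which shows only that the hydroxyphenyl group does not by itself fix where a compound falls.

Going by the values given here, with no direct precedent, compound 4 is expected to stay close to compound 1, and the estimated step of a 1.3-fold higher number from compound 1 to compound 4 (0.10 log units; within the scatter) is taken as one within the usual scatter. The estimate for compound 4 is 25 ug/mL, with a range from 8 ug/mL to 100 ug/mL.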

Compound 4, minimum cytotoxic concentration: 20 ug/mL
Compound 4: middle estimate off by 1.3-fold (0.10 log units), on the high side; the range from low to high includes it.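

In this assay, going from the 4-hydroxyphenyl group to phenyl, with hydrogen taking the place of hydroxy on an aromatic carbon para to a large group, gives no change at the digits printed from compound 1 to compound 4 (within the scatter). Within the data shown here, this is the first comparison that can be read as a size, as the earlier one between two limits cannot, and it shows that on this core the hydroxy is not required for a cytotoxicity reading of this size, even though it is the only hydrogen-bond donor that leaves in this change. Nothing measured here offers a cause for this result.

From the compounds shown here alone, only hydrogen and hydroxy have been compared at this position, so it remains open how this core would read with a different group there, such as an amine or a carboxylic acid on the same ring. Also open, going by these compounds, is whether the same swap would read alike on the differently arranged core of compound 3, whose value is a limit and not a number.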